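Acetylating the hydroxyl of compound 2

A few compounds are considered here, and "the series" means these few. Any claim that something is new, unique, unknown or untested is made for them only; others in the source may bear on it.

Measured so far in a functional assay on HCT-116 cells (Homo sapiens) for antiproliferative activity, read by sulforhodamine B assay, with a stated time of 72 h; on this read-out lower numbers stand for stronger inhibition and higher numbers for weaker inhibition
- compound 1 `CNC(=O)C[C@@H]1C[C@@H](c2ccc(Cl)c(Cl)c2)[C@H](NC(=O)c2cc(-c3c(Cl)cnn3C)c(Cl)o2)CN1` gives 450 nM
- compound 2 `Cn1ncc(Cl)c1-c1cc(C(=O)N[C@@H]2CN[C@H](CCO)C[C@H]2c2ccc(F)c(F)c2)oc1Cl` gives 360 nM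
- compound 3 `Cn1ncc(Cl)c1-c1cc(C(=O)N[C@@H]2CN[C@H](CCO)C[C@H]2c2ccc(Cl)c(Cl)c2)oc1Cl` gives 340 nM

Compound 2 at 360 nM lies within the scatter of both other compounds. Compound 4 `CC(=O)OCC[C@@H]1C[C@@H](c2ccc(F)c(F)c2)[C@H](NC(=O)c2cc(-c3c(Cl)cnn3C)c(Cl)o2)CN1` carries 2-acetoxyethyl where compound 2 has 2-hydroxyethyl, with acetyl in place of hydrogen on an oxygen on a saturated carbon. Among the measured compounds shown here, no measured step covers this change directly. Hydroxymethyl in place of methylcarbamoyl gave a 1.3-fold lower number from compound 1 to compound 3 (0.12 log units; within the scatter) and 3,4-dichlorophenyl in place of 3,4-difluorophenyl gave a 1.1-fold lower number from compound 2 to compound 3 (0.02 log units; within the scatter) and both stay within the scatter. In this assay the expected result is a 1.1-fold higher number from compound 2 to compound 4 (0.05 log units; within the scatter) and no step beyond the scatter is anticipated. Compound 4 is expected at 400 nM with a range from 170 nM to 900 nM on this estimate.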

Compound 4, half-maximal inhibitory concentration: 690 nM
Beside the measured number, compound 4's estimate is 1.7-fold (0.24 log units) below it; low and high end bracket the measured number.
By their numbers in this assay, from the lowest: compounds 3, 2, 1 and 4 (each within the scatter of the next, the first and the last beyond it).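

In this assay, acetyl in place of hydrogen on the oxygen of the 2-hydroxyethyl chain gives a 1.9-fold higher number from compound 2 to compound 4 (0.28 log units; within the scatter). The earlier steps shown here exchanged methylcarbamoyl for hydroxymethyl and 3,4-difluorophenyl for 3,4-dichlorophenyl, so neither tested a change on this oxygen. With 2-acetoxyethyl in this position, the hydrogen on the oxygen is shown not to be needed for a number within the scatter of compound 2.

On these data alone, whether an amine, a carboxylic acid or a longer chain at this position would also stay within the scatter remains open. No available measurement explains the size of this step.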